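This account rests on a few compounds, and the source may have more. Where it says the series, first, only, none or still open, it means among the compounds named here.

Of the compounds shown here, three on a shared core have numbers so far in an ADME assay on S9 fraction from liver (Rattus norvegicus) for metabolic stability, read by LC-MS, using NADPH, with a stated time of 60 min, tested at 10 uM (on this read-out higher numbers stand for a more stable compound and lower numbers for a less stable compound), for this comparison. There compound 1 `N#CC1(c2cc(CCO)cc(-c3ccnc4[nH]nc(C(F)(F)F)c34)c2)CC1` gives 17% and compound 2 `C[C@@H](O)Cc1cc(-c2ccnc3[nH]nc(C(F)(F)F)c23)cc(C2(C#N)CC2)c1` gives 42% while compound 3 `COCCc1cc(-c2ccnc3[nH]nc(C(F)(F)F)c23)cc(C2(C#N)CC2)c1` gives 90% as the highest of the three numbers, with both others beyond the scatter from it.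

The next structure is compound 4 `N#CC1(c2cc(CCF)cc(-c3ccnc4[nH]nc(C(F)(F)F)c34)c2)CC1` with fluoro in place of methoxy on a saturated chain carbon, two bonds along the chain from an aromatic carbon so that 2-methoxyethyl becomes 2-fluoroethyl.

All measured steps fall on this same chain. Methyl in place of the hydroxyl hydrogen gave a number 73 percentage points higher from compound 1 to compound 3 (beyond the scatter) and methyl on the chain carbon bound to the oxygen gave a number 25 percentage points higher from compound 1 to compound 2 (beyond the scatter) while the remaining pair shows a number 48 percentage points higher from compound 2 to compound 3 (beyond the scatter) as its step. Compound 4, like compound 3, carries no hydroxyl, unlike compound 1 and compound 2. Within the data shown here, no measured compound carries fluoro on this chain, so the swap itself is untested. A small fall, not beyond the scatter, is therefore expected, and the estimated change is a number 8 percentage points lower from compound 3 to compound 4 (within the scatter) in this comparison. The estimate for compound 4 is 82% with an expected range from 62% to 96% on this read-out.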

Compound 4, percent of the compound remaining: 67%
Beside the measured number, compound 4's estimate is 15 percentage points above it, and the stated range covers the measured number.
By their numbers in this assay, from the lowest: compound 1; then compound 2; then compound 4; then compound 3.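

In this assay, fluoro in place of methoxy on a saturated chain carbon, two bonds along the chain from an aromatic carbon, gives a number 23 percentage points lower from compound 3 to compound 4 (beyond the scatter) and so shows that chains without a hydroxyl are not interchangeable at this position: what replaces the hydroxyl matters as well as its absence. Fluoro in place of hydroxy gives a number 50 percentage points higher from compound 1 to compound 4 (beyond the scatter) and the comparison with the branched alcohol gives a number 25 percentage points higher from compound 2 to compound 4 (beyond the scatter) on the same read-out, which places compound 4 above both hydroxyl compounds and below compound 3, so a high number here does not depend on the added carbon that methoxy carries. Nothing in the information at hand accounts for this order.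

Going by these compounds, it remains open whether a longer ether chain such as 2-ethoxyethyl would keep or exceed the number of compound 3, and how an amine or a carboxylic acid would fare in the same place. Also open, on these data alone, is whether a methyl on the chain carbon bearing the fluoro would shift compound 4 in the way the same methyl shifted the alcohol, as seen in a number 25 percentage points higher from compound 1 to compound 2 (beyond the scatter) on this read-out.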